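A few compounds are considered here, and "the series" means these few. Any claim that something is new, unique, unknown or untested is made for them only; others in the source may bear on it.

Compound 3 `CC(=O)c1cc(C(C)=O)c(OCCCCC#N)cc1O` gives 0% in an assay on isolated protein for binding affinity to leukotriene B4 receptor 1 (Homo sapiens), tested at 1 uM (on this read-out lower numbers stand for less inhibition and higher numbers for more inhibition at the one concentration tested (going by the name of the read-out)), level with compound 1 `CC(=O)c1ccc(OCCCCC#N)cc1O`, which gives 0%, and together these two stand as the lowest of the three numbers, while compound 2 `CCCCCc1cc(C(C)=O)c(O)cc1OCCCCC#N` gives 14%. Compound 4 `C=CCc1cc(C(C)=O)c(O)cc1OCCCCC#N` differs from compound 3 by allyl in place of acetyl on an aromatic carbon. For the measured compounds named here, two measured steps bear on this change: a number 14 percentage points lower from compound 2 to compound 3 (beyond the scatter), and a number 14 percentage points higher from compound 1 to compound 2 (beyond the scatter); in contrast, no change at the digits printed from compound 1 to compound 3 (within the scatter). A carbon chain at this aromatic carbon thus went with a modest gain, whereas acetyl and hydrogen were alike; allyl is a shorter chain than pentyl, so a smaller rise, a number 7 percentage points higher from compound 3 to compound 4 (within the scatter), is expected for compound 4. Compound 4 is accordingly estimated at 7%, within a range of 0% to 20%.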

Compound 4, a percentage reported as inhibition, at one concentration (the size of the read-out at that concentration, not a potency): 57%
Estimate against measurement, compound 4: 50 percentage points below; the measured number lies above the stated range.
By their numbers in this assay, from the lowest: compounds 1 and 3 (each within the scatter of the next); then compound 2; then compound 4.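

In this assay, for the compounds shown here, the aromatic carbon para to a hydroxy group proves far more responsive than the earlier compounds showed, with allyl giving a large gain over both hydrogen (a number 57 percentage points higher from compound 1 to compound 4 (beyond the scatter)) and acetyl (a number 57 percentage points higher from compound 3 to compound 4 (beyond the scatter)). Allyl also surpasses pentyl (a number 43 percentage points higher from compound 2 to compound 4 (beyond the scatter)), so between these two chains the longer one does not give the higher number. No evidence at hand accounts for this rise. Whether the gain depends on the double bond remains open, since propyl, the saturated counterpart of allyl, is not among the compounds shown. Also open, as far as these compounds go, is how a longer chain ending in a double bond would compare.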